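Swapping methoxy for cyano on the aryl ring of compound 3

A few compounds are considered here, and "the series" means these few. Any claim that something is new, unique, unknown or untested is made for them only; others in the source may bear on it.

The series shares one core, seen in compound 1 `CCOC(=O)c1c(-c2ccc(OC)c(OC)c2)csc1N`, compound 2 `COc1ccc(-c2csc(N)c2C(=O)OCc2ccncc2)cc1OC` and compound 3 `CCOC(=O)c1c(-c2cccc(OC)c2)csc1N`. In an assay on isolated protein for inhibition of protein kinase C zeta type (Homo sapiens), with stated times of 1 h and 2.5 min, tested at 30 uM (on this read-out higher numbers stand for more inhibition at the one concentration tested (going by the name of the read-out) and lower numbers for less inhibition), compound 1 gives 100%, compound 2 gives 53% and compound 3 gives 82%. Among these three numbers compound 3 stands second highest: compound 1 lies above it and compound 2 below it, both gaps beyond the scatter. The two measured steps are a number 47 percentage points lower from compound 1 to compound 2 (beyond the scatter), with pyridin-4-yl in place of methyl on a saturated chain carbon bound to an oxygen next to a carbonyl group, and a number 18 percentage points lower from compound 1 to compound 3 (beyond the scatter), with hydrogen in place of methoxy on an aromatic carbon.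

Compound 4 `CCOC(=O)c1c(-c2cccc(C#N)c2)csc1N` has not yet been measured in this assay. It differs from compound 3 by cyano in place of methoxy on an aromatic carbon, on an aromatic carbon of a six-membered aromatic ring of carbon only, meta to a large group. Among the measured compounds shown here, no measured step changes this position in the same way; the nearest is the loss of a methoxy from compound 1 to compound 3, which was modest. Since cyano also brings one hydrogen-bond acceptor and no ring, a step of a number 10 percentage points lower from compound 3 to compound 4 (within the scatter) is expected, small and within or near the scatter. Compound 4 is therefore estimated at 72%, with a range from 45% to 95%.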

Compound 4, a percentage reported as inhibition, at one concentration (the size of the read-out at that concentration, not a potency): 32%
Estimate against measurement, compound 4: 40 percentage points above; measured number outside the range, below it.
By their numbers in this assay, from the lowest: compound 4; then compound 2; then compound 3; then compound 1.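

In this assay, among the compounds shown here, cyano in place of methoxy on this aromatic carbon, meta to a large group, gives a number 50 percentage points lower from compound 3 to compound 4 (beyond the scatter), so the read-out depends strongly on what this carbon carries, something the earlier steps could not show, as neither of them replaced a group here. Methoxy and cyano have the same counts of heavy atoms and hydrogen-bond acceptors, neither brings a ring or a net charge, and so these counts do not separate compound 3 from compound 4, even though the step between them is large. No evidence at hand bears on the reason for this step.

The compounds shown leave open whether an ethoxy, a hydroxyl or an amine on this carbon would stay close to compound 3 or fall as far as compound 4, and whether plain hydrogen here would tell the loss of methoxy apart from the arrival of cyano. They also leave open whether the same swap would cost as much with the second methoxy of compound 1 in place or with the pyridin-4-yl group of compound 2.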